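The source may report more compounds than this note shows. Statements on the series, on what has been measured and on what is new or still open speak of the compounds shown alone.

Compound 1 `COc1ccc(C[C@@H](O)/C=C/C=C/C(=O)N2CCN(C)CC2)cc1OC`, compound 2 `COc1ccc(C[C@@H](O)/C=C/C=C/C(=O)N2CCN(c3ccccc3)CC2)cc1OC` and compound 3 `CCN1CCN(C(=O)/C=C/C=C/[C@H](O)Cc2ccc(OC)c(OC)c2)CC1` share one core and differ only in the group on an amine nitrogen in a ring: methyl, phenyl and ethyl. In a functional assay on MCF7 cells (Homo sapiens) for antiproliferative activity, read by sulforhodamine B assay, with a stated time of 48 h (on this read-out lower numbers stand for stronger inhibition and higher numbers for weaker inhibition), compound 1 gives 17100 nM, compound 2 gives 12000 nM and compound 3 gives 11500 nM. Compound 3 therefore stands level with the other two, as all three numbers lie within the usual scatter of one another.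

Compound 4 `COc1ccc(C[C@@H](O)/C=C/C=C/C(=O)N2CCN(c3ccccn3)CC2)cc1OC` has not yet been measured. The change that leads to it is pyridin-2-yl in place of ethyl on an amine nitrogen in a ring.

For the measured compounds named here, three measured steps bear on this change. Putting phenyl in place of methyl gave a 1.4-fold lower number from compound 1 to compound 2 (0.15 log units; within the scatter), putting ethyl in place of phenyl gave a 1.0-fold lower number from compound 2 to compound 3 (0.02 log units; within the scatter), and going from methyl to ethyl gave a 1.5-fold lower number from compound 1 to compound 3 (0.17 log units; within the scatter). All three stay within the scatter, so exchanging these groups has not yet shifted the read-out measurably. Going by the values given here, no tested compound carries pyridin-2-yl, so the nearest guide is the phenyl group of compound 2 at 12000 nM. No shift beyond the scatter is therefore expected in this assay.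

The expected step is a 1.0-fold higher number from compound 3 to compound 4 (0.02 log units; within the scatter). For compound 4 the estimated value is 12000 nM, with an expected range from 6000 nM to 24000 nM.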

Compound 4, half-maximal inhibitory concentration: 23600 nM
Beside the measured number, compound 4's estimate is 2.0-fold (0.29 log units) below it; the range from low to high includes it.
By their numbers in this assay, from the lowest: compounds 3, 2, 1 and 4 (each within the scatter of the next, the first and the last beyond it).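

In this assay, this position on an amine nitrogen in a ring now gives its first step beyond the scatter: pyridin-2-yl in place of ethyl produces a 2.1-fold higher number from compound 3 to compound 4 (0.31 log units; beyond the scatter), a modest step. The other two exchanges stay within the scatter, with pyridin-2-yl in place of phenyl giving a 2.0-fold higher number from compound 2 to compound 4 (0.29 log units; within the scatter) and pyridin-2-yl in place of methyl giving a 1.4-fold higher number from compound 1 to compound 4 (0.14 log units; within the scatter), so compound 4 is separated only from compound 3 and cannot be told apart from compound 1 or compound 2. Among the four compounds, this position therefore shows a small effect for one pair only, and nothing available explains why that exchange reaches beyond the scatter.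

Going by these compounds, it remains open whether any other group on this nitrogen, such as benzyl, acetyl or a longer chain ending in an amine, would move the number further than this modest step. On these data alone, it also remains open whether the step from ethyl to pyridin-2-yl would recur if the hydroxyl group elsewhere in the shared core were replaced by a ketone.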